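From Phenyl to 2-Chlorobenzyl on a Nitrogen

A few compounds are considered here, and "the series" means these few. Any claim that something is new, unique, unknown or untested is made for them only; others in the source may bear on it.

Two compounds open this story, and neither provides an exact potency. In a functional assay on MOLT-4 cells (Homo sapiens) for antiproliferative activity, read by MTT assay, with a stated time of 48 h (on this read-out lower numbers stand for stronger inhibition and higher numbers for weaker inhibition), compound 1 `Fc1cnc(Nc2cn[nH]c2)nc1Nc1ccc(Cl)cc1` has the entry "not determined" (no result reported), so it offers no comparison. Compound 2 `c1ccc(Nc2nc(Nc3cn[nH]c3)nc3[nH]ccc23)cc1` gives > 5000 nM, which is a limit of this assay and not a number. That limit is the only starting point for what follows.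

The next compound, compound 3 `Clc1ccccc1CNc1nc(Nc2cn[nH]c2)nc2[nH]ccc12`, has 2-chlorobenzyl in place of phenyl on a nitrogen on an aromatic ring. Among the compounds with values here, no measured step between two compounds is available as a guide, so any forecast here is tentative. A modest change toward stronger inhibition is expected, and the estimated step is an at least 1.2-fold lower number from compound 2 to compound 3 (0.09 log units; that floor lies within the scatter). It may also turn out to be no larger than the usual scatter. For compound 3, the expected value is 4000 nM, with an estimated range of 800 nM to 15000 nM.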

Compound 3, half-maximal inhibitory concentration: > 5000 nM
Compound 3: a limit, no number (the forecaster's own chance of this, stated with the estimate: 45%); middle value at least 1.2-fold (0.09 log units) from the limit.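

No step from compound 2 to compound 3 can be read in this assay because both entries are limits and not numbers: the limit of > 5000 nM in this assay, at which 2 of the 3 values shown sit.

The compounds shown leave open whether 2-chlorobenzyl in place of phenyl on a nitrogen on an aromatic ring changes inhibition at all, and in which direction.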